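Swapping the aryl group on the sulfonamide of a hydroxamate

A few compounds are considered here, and "the series" means these few. Any claim that something is new, unique, unknown or untested is made for them only; others in the source may bear on it.

Compound 2 `CC[C@H](C)[C@H](NS(=O)(=O)c1cc(Br)c(Br)s1)C(=O)N[C@@H](CNC(=O)OCc1ccccc1)C(=O)NO` gives 52 nM in an assay on isolated protein for inhibition of bone morphogenetic protein 1 (Homo sapiens) (on this read-out higher numbers stand for weaker inhibition and lower numbers for stronger inhibition), the lowest of the two numbers shown, yet only within the scatter of compound 1 `CC[C@H](C)[C@H](NS(=O)(=O)c1cc(C)c(Cl)cc1C)C(=O)N[C@@H](CNC(=O)OCc1ccccc1)C(=O)NO`, which gives 67 nM; the change was a 1.3-fold lower number from compound 1 to compound 2 (0.11 log units; within the scatter). Compound 3 `CC[C@H](C)[C@H](NS(=O)(=O)c1cc(Cl)ccc1Cl)C(=O)N[C@@H](CNC(=O)OCc1ccccc1)C(=O)NO` carries 2,5-dichlorophenyl in place of 4,5-dibromothiophen-2-yl on a sulfonyl sulfur. Among the measured compounds shown here, the single comparable step, an aryl exchange at the same sulfonyl sulfur, stayed within the scatter, so no shift beyond the scatter is expected in this assay. Compound 3 is therefore estimated at 60 nM, between 25 nM and 150 nM, an expected step of a 1.2-fold higher number from compound 2 to compound 3 (0.06 log units; within the scatter).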

Compound 3, half-maximal inhibitory concentration: 65 nM
The estimate for compound 3 lay 1.1-fold (0.03 log units) below the measured number; the range from low to high includes it.
By their numbers in this assay, from the lowest: compounds 2, 3 and 1 (each within the scatter of the next).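

In this assay, 2,5-dichlorophenyl in place of 4,5-dibromothiophen-2-yl gave a 1.3-fold higher number from compound 2 to compound 3 (0.10 log units; within the scatter), and the same group in place of 4-chloro-2,5-dimethylphenyl gave a 1.0-fold lower number from compound 1 to compound 3 (0.01 log units; within the scatter). On the sulfonyl sulfur, a second six-membered aromatic ring of carbon only, carrying two chlorines and no methyl, therefore also stays within the scatter of both other aryl groups. Nothing available explains why these three groups read alike. Whether an aryl group bearing an amine or a carboxylic acid would remain within that scatter is open, as is the outcome for a plain alkyl chain on the sulfonyl sulfur.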